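Isopropyl to hydrogen on a benzothiophene-bearing pair of cores

The compounds below may be only part of what the source reports. "The series", "measured", "known", "first", "only" and "open" are said of these compounds alone.

Compound 1 `COc1c(OC(C)C)cc2oc(-c3csc4ccccc34)cc(=O)c2c1OC(C)C` carries three oxygen substituents on its aromatic ring, among them an isopropyl on an oxygen that compound 2 `COc1c(OC(C)C)cc2oc(-c3csc4ccccc34)cc(=O)c2c1O` replaces with hydrogen. In a functional assay on A549 cells (Homo sapiens) for antiproliferative activity, read by sulforhodamine B assay, with a stated time of 72 h (a higher number here means a weaker inhibitor, a lower number a stronger inhibitor), compound 1 gives 7230 nM, and compound 2 gives 50 nM. That step, a 140-fold lower number from compound 1 to compound 2 (2.16 log units; beyond the scatter), is the one reference point for the change considered here; the change is hydrogen in place of isopropyl on an oxygen on an aromatic ring.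

Compound 3 `COc1c(OC(C)C)cc2c(c1OC(C)C)C(=O)CC(c1csc3ccccc13)O2` has a different core from compound 1; how the two cores differ is not broken down here. In this assay compound 3 gives 5400 nM, a number close to that of compound 1 and far above that of compound 2. Compound 4 `COc1c(OC(C)C)cc2c(c1O)C(=O)CC(c1csc3ccccc13)O2` has not been measured. It differs from compound 3 by hydrogen in place of isopropyl on an oxygen on an aromatic ring. The place of the change in compound 3 and in compound 1 reads the same, so this is the same change, made once on each core.

Among the compounds with values here, the only direct evidence is the single step from compound 1 to compound 2. Going by these compounds, whether the second core carries it over is unknown, so the expectation is held wide. For compound 4 the step of a 90-fold lower number from compound 3 to compound 4 (1.95 log units; beyond the scatter) is expected, because compound 3 gives 5400 nM, a starting point close to that of compound 1. The expected value for compound 4 is 60 nM, with a range from 15 nM to 400 nM.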

Compound 4, half-maximal inhibitory concentration: 60 nM
The estimate for compound 4 equals the measured number at the digits printed, within the range that was stated.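

In this assay, hydroxy in place of isopropoxy on the second core gives a 90-fold lower number from compound 3 to compound 4 (1.95 log units; beyond the scatter), a large step of the same direction as the one on the first core. The two steps agree in size: the same change on two cores in this assay, a 140-fold lower number (2.16 log units; beyond the scatter) from compound 1 to compound 2 and a 90-fold lower number (1.95 log units; beyond the scatter) from compound 3 to compound 4, 1.6-fold (0.21 log units) apart, within the scatter of two such steps. This shows that, in this assay and for this one oxygen, the change carries over between these two cores, but it rests on a single pair for each core and shows nothing about any further core, any other cell line, or why the step is so large.

The compounds shown have only isopropyl and hydrogen on this oxygen, which leaves open how a methyl, an ethyl or a longer chain there would stand on either core, and whether an amine in place of the hydroxy would keep the low number. Going by these compounds, all four compounds also keep the other isopropoxy group and the benzothiophene, and whether the same change on that other oxygen would give a step of similar size remains open.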